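A few compounds are considered here, and "the series" means these few. Any claim that something is new, unique, unknown or untested is made for them only; others in the source may bear on it.

Values in a functional assay on HeLa cells (Homo sapiens), read by colorimetric assay, with a stated time of 72 h; on this read-out higher numbers stand for an effect only at larger amounts of compound and lower numbers for an effect already at smaller amounts:
- compound 1 `FCc1cn(Cc2ccccc2)nn1`: > 100 ug/mL (a limit)
- compound 2 `CC(=O)OC[C@H]1O[C@@H](n2cc(CCl)nn2)[C@H](OC(C)=O)[C@@H](OC(C)=O)[C@@H]1OC(C)=O`: 37 ug/mL
- compound 3 `CC(=O)N[C@@H]1[C@@H](OC(C)=O)[C@H](OC(C)=O)[C@@H](COC(C)=O)O[C@H]1n1cc(CCl)nn1`: 20 ug/mL

Compound 2 stands level with compound 3, since the step of a 1.9-fold lower number from compound 2 to compound 3 (0.27 log units; within the scatter) does not separate them. Compound 4 `CC(=O)OC[C@H]1O[C@@H](n2nncc2CCl)[C@H](OC(C)=O)[C@@H](OC(C)=O)[C@@H]1OC(C)=O` has the same atoms as compound 2, joined differently: 5-(chloromethyl)-1H-1,2,3-triazol-1-yl in place of 4-(chloromethyl)-1H-1,2,3-triazol-1-yl on a saturated ring carbon, next to the ring oxygen. Going by the values given here, the only measured step, a 1.9-fold lower number from compound 2 to compound 3 (0.27 log units; within the scatter), concerns acetamido in place of acetoxy, so it bears on this change only indirectly. Among the compounds with values here, no step on the triazole itself has been measured, so no shift beyond the scatter and no direction is expected in this assay. The expected change is a 1.1-fold lower number from compound 2 to compound 4 (0.02 log units; within the scatter). For compound 4 the estimated value is 35 ug/mL, with an expected range of 12 ug/mL to 90 ug/mL.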

Compound 4, concentration for half-maximal effect: 25 ug/mL
Compound 4: the middle estimate sits 1.4-fold (0.15 log units) above what was measured, and the stated range covers the measured number.
By their numbers in this assay, from the lowest: compounds 3, 4 and 2 (each within the scatter of the next). At a limit, above all of these: compound 1.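

In this assay, 5-(chloromethyl)-1H-1,2,3-triazol-1-yl in place of 4-(chloromethyl)-1H-1,2,3-triazol-1-yl gives a 1.5-fold lower number from compound 2 to compound 4 (0.17 log units; within the scatter) and so does not separate the two arrangements. Going by these compounds alone, this is the first reading on this change itself: at this saturated ring carbon, next to the ring oxygen, the swap leaves the value within the scatter. Nothing measured here accounts for this result. Open, as far as these compounds go, is whether the same swap reads alike with acetamido in place of acetoxy, as in compound 3. Also open, from the compounds shown here alone, is what an aminomethyl group or a longer chain would give in place of chloromethyl.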